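Moving the Fluorine Around the Sulfonyl Aryl Ring

This account rests on a few compounds, and the source may have more. Where it says the series, first, only, none or still open, it means among the compounds named here.

Among the compounds with values here, compound 1 `NCCn1cc(S(=O)(=O)c2cccc(F)c2)c2cccnc21` is the only compound here with a measured number. In a functional assay on HeLa cells for agonist activity at 5-hydroxytryptamine receptor 6 (Homo sapiens), read by immunoassay (a higher number here means that more compound is needed for the effect, a lower number that less compound is needed), compound 1 gives 24 nM, so it is the sole reference point for what follows. A second compound, compound 2 `O=S(=O)(c1cccc(F)c1)c1cn(CCN2CCCC2)c2ncccc12`, was also studied, but in this assay compound 2 has "not determined" (no result reported), so it adds nothing to the comparison.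

Compound 3 `NCCn1cc(S(=O)(=O)c2ccc(F)cc2)c2cccnc21` has the same atoms as compound 1, joined differently: 4-fluorophenyl in place of 3-fluorophenyl on a sulfonyl sulfur. Within the data shown here, no measured pair of compounds here shows this kind of change, so its effect has to be guessed. Such a shift of a single fluorine usually moves potency only modestly, and the step from compound 1 to compound 3 is expected to be a 1.3-fold higher number from compound 1 to compound 3 (0.10 log units; within the scatter), within the usual scatter. Compound 3 is therefore estimated at 30 nM in this assay, with a likely range of 8 nM to 120 nM.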

Compound 3, half-maximal effective concentration: 166 nM
Compound 3: middle estimate off by 5.5-fold (0.74 log units), on the low side; measured number outside the range, above it.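

Moving a single fluorine, with the atoms themselves unchanged, is not a neutral change at this position. In this assay, 4-fluorophenyl in place of 3-fluorophenyl on a sulfonyl sulfur gives a 6.9-fold higher number from compound 1 to compound 3 (0.84 log units; beyond the scatter) and so more compound is needed for the effect once the fluorine has moved. For this one pair, then, the aryl ring on the sulfonyl sulfur is sensitive to where its fluorine sits, and nothing available here bears on why the two placements differ.

Still open, from the compounds shown here alone, is how other groups on that ring would compare, such as a plain phenyl or a 3-chlorophenyl. It is also unknown whether the fluorine shift would matter as much if the aminoethyl chain gave way to a longer chain carrying the same amine.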